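Isobutyl to 4-hydroxyphenyl in the amidine series

The compounds below may be only part of what the source reports. "The series", "measured", "known", "first", "only" and "open" are said of these compounds alone.

Measured in an in vivo ADME assay on the whole organism (Cavia porcellus); a higher number here means that the compound lasts longer, a lower number that the compound disappears faster
- compound 1 `CCCC(NC(=O)c1ccc(C(=N)N)cc1)C(C)(C)C(=O)N1CCC(CC(=O)O)CC1` gives 0.9 h
- compound 2 `CCCCC(NC(=O)c1ccc(C(=N)N)cc1)C(C)(C)C(=O)N1CCC(CC(=O)O)CC1` gives 1.03 h
- compound 3 `CC(C)CC(NC(=O)c1ccc(C(=N)N)cc1)C(C)(C)C(=O)N1CCC(CC(=O)O)CC1` gives 0.917 h

Compound 3 at 0.917 h cannot be told apart from the other two, as it lies within the scatter of both. The next change leads to compound 4 `CC(C)(C(=O)N1CCC(CC(=O)O)CC1)C(NC(=O)c1ccc(C(=N)N)cc1)c1ccc(O)cc1` and reads 4-hydroxyphenyl in place of isobutyl on a saturated chain carbon bound to an amide-type nitrogen and a saturated chain carbon with 4-hydroxyphenyl in place of isobutyl on a saturated chain carbon bound to an amide-type nitrogen and a saturated chain carbon.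

For the measured compounds named here, three measured steps bear on this change (a 1.1-fold higher number from compound 1 to compound 2 (0.06 log units; within the scatter)) (a 1.0-fold higher number from compound 1 to compound 3 (0.01 log units; within the scatter)) (a 1.1-fold lower number from compound 2 to compound 3 (0.05 log units; within the scatter)) and all of them exchange one saturated chain for another. Going by the values given here, no measured compound has an aromatic ring at this place, so these steps are only a weak guide. On their size, no shift beyond the scatter is expected in this assay for now. The expected step, by estimate, is a 1.1-fold lower number from compound 3 to compound 4 (0.06 log units; within the scatter) with wide uncertainty. For compound 4 the estimated half-life is 0.8 h with an expected range from 0.4 h to 1.6 h in this estimate.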

Compound 4, half-life: 1.05 h
Compound 4: the middle estimate sits 1.3-fold (0.12 log units) below what was measured; low and high end bracket the measured number.
By their numbers in this assay, from the lowest: compounds 1, 3, 2 and 4 (each within the scatter of the next).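

In this assay, the first aromatic ring at this place, 4-hydroxyphenyl on a saturated chain carbon bound to an amide-type nitrogen and a saturated chain carbon, gives no step beyond the scatter against any of the saturated chains: isobutyl (a 1.1-fold higher number from compound 3 to compound 4 (0.06 log units; within the scatter)), butyl (a 1.0-fold higher number from compound 2 to compound 4 (0.01 log units; within the scatter)) and propyl (a 1.2-fold higher number from compound 1 to compound 4 (0.07 log units; within the scatter)). The half-life therefore stays within the scatter across compounds 1 to 4, even though the change brings in a six-membered aromatic ring and a hydroxyl group together. No data on why the half-life holds at this place accompany these compounds.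

The compounds shown do not separate the ring from its hydroxyl group, which an unsubstituted phenyl would address. On these data alone, whether an amine or a carboxylic acid on that ring would shift the half-life also remains open.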